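Replacing the hydroxyphenyl of compound 3 with a fluoromethylphenyl

A few compounds are considered here, and "the series" means these few. Any claim that something is new, unique, unknown or untested is made for them only; others in the source may bear on it.

Three compounds of the shared core carry the same trimethoxyphenyl and differ only in the aryl group on the fused ring. Compound 1 `COc1cc(-n2cnc3ccc(-c4ccc(C(F)(F)F)cc4)cc32)cc(OC)c1OC` gives 890 nM in a functional assay on SGC-7901 cells (Homo sapiens) for antiproliferative activity, read by MTT assay, with a stated time of 72 h; a higher number here means a weaker inhibitor, a lower number a stronger inhibitor. Compound 2 `COc1cc(-n2cnc3ccc(-c4cccc([N+](=O)[O-])c4)cc32)cc(OC)c1OC` gives 380 nM in this assay, a step of a 2.3-fold lower number from compound 1 to compound 2 (0.37 log units; beyond the scatter). Compound 3 `COc1cc(-n2cnc3ccc(-c4ccc(O)cc4)cc32)cc(OC)c1OC` sits at the limit of this assay, > 10000 nM; this is a limit, not a number, and compound 3 is the only one of the three at the limit of > 10000 nM in this assay, at which 1 of the 3 values shown sits. Compound 3 thus stands as the weakest of the measured set: the steps of an at least 11-fold higher number from compound 1 to compound 3 (1.05 log units; beyond the scatter) and an at least 26-fold higher number from compound 2 to compound 3 (1.42 log units; beyond the scatter) are both beyond the scatter and both large.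

Compound 4 `COc1cc(-n2cnc3ccc(-c4ccc(C)cc4F)cc32)cc(OC)c1OC` is not yet measured. It differs from compound 3 by 2-fluoro-4-methylphenyl in place of 4-hydroxyphenyl on an aromatic carbon. The two measured steps already described bear on this change, an at least 11-fold higher number from compound 1 to compound 3 (1.05 log units; beyond the scatter) and an at least 26-fold higher number from compound 2 to compound 3 (1.42 log units; beyond the scatter): each removes a trifluoromethyl or nitro group in favour of a hydroxy. Compound 4 takes the hydroxy out again and returns to a substituted aryl without donor or acceptor, so a return toward the range of compounds 1 and 2 is expected, a step of an at least 16-fold lower number from compound 3 to compound 4 (1.22 log units; beyond the scatter). Compound 4 is expected at 600 nM, within 200 nM to 3000 nM.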

Compound 4, half-maximal inhibitory concentration: 5650 nM
Compound 4: the middle estimate sits 9.4-fold (0.97 log units) below what was measured; measured number above the stated range.
By their numbers in this assay, from the lowest: compound 2; then compound 1; then compound 4. At a limit, above all of these: compound 3.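

Compound 3 stands at a limit of this assay, not at a number: (the limit of > 10000 nM in this assay, at which 1 of the 4 values shown sits). Exchanging its 4-hydroxyphenyl for 2-fluoro-4-methylphenyl gives only a floor for the change (an at least 1.7-fold lower number from compound 3 to compound 4 (0.24 log units; that floor lies within the scatter)), so this pair does not show that taking out the hydroxy recovers much activity at this position. The new information lies among the aryl groups without a hydroxy, which are not interchangeable here: 2-fluoro-4-methylphenyl falls well behind 3-nitrophenyl (a 15-fold higher number from compound 2 to compound 4 (1.17 log units; beyond the scatter)) and behind 4-(trifluoromethyl)phenyl (a 6.3-fold higher number from compound 1 to compound 4 (0.80 log units; beyond the scatter)), so compound 4 goes against any reading in which the hydroxy alone separates compound 3 from compound 1 and compound 2.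

Compound 4 changes the fluoro and the methyl together, and the compounds shown cannot divide its loss between those two substituents or separate the identity of a substituent from its place on the aryl ring. How a plain 4-methylphenyl, a 3-aminophenyl or an aryl group bearing a carboxylic acid would behave at this position remains open, as does any cause for the order seen.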